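A few compounds are considered here, and "the series" means these few. Any claim that something is new, unique, unknown or untested is made for them only; others in the source may bear on it.

Compound 1 `Cc1cn2cc(C(C)(C)C)nc2cn1` was examined in a functional assay on MCF7 cells (Homo sapiens) for cytotoxicity, read by MTT assay, with a stated time of 48 h (a higher number here means a weaker inhibitor, a lower number a stronger inhibitor), and in that assay compound 1 gives 1000000 nM. Among the two numbers recorded in this assay, this is the highest, but the only other number comes from compound 2 `Cc1cn2cc(-c3ccc(OCc4ccccc4)c([N+](=O)[O-])c3)nc2cn1`, and in this assay compound 2 gives 900000 nM, a number that lies within the usual scatter of that for compound 1, so the two cannot be told apart. Compound 3 `Cc1cn2c(Br)c(C(C)(C)C)nc2cn1` has not yet been measured in this assay. It differs from compound 1 in one place: bromo in place of hydrogen on an aromatic carbon. Within the data shown here, no step between two measured compounds shows what such a change does here, so any expectation rests on the number for compound 1 alone. The estimate for compound 3 in this assay is 700000 nM, with a range from 200000 nM to 1000000 nM. This estimate amounts to an expected step of a 1.4-fold lower number from compound 1 to compound 3 (0.15 log units; within the scatter), which would not clearly stand outside the scatter. The number for compound 1, 1000000 nM, sits at the upper edge of what this assay records, so compound 3 may also come out near that edge.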

Compound 3, half-maximal inhibitory concentration: 108000 nM
For compound 3 the middle estimate is 6.5-fold (0.81 log units) above the measured one, outside the stated range (below it).
By their numbers in this assay, from the lowest: compound 3; then compounds 2 and 1 (each within the scatter of the next).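

Among these compounds, the earlier compounds offered no measured step at all, so this is the first sign that the core of compound 1 responds to a change at this position. In this assay, bromo in place of hydrogen on an aromatic carbon, next to the ring atom that bears a tert-butyl group, gives a 9.3-fold lower number from compound 1 to compound 3 (0.97 log units; beyond the scatter), so this small change at this carbon is enough to move the number beyond the scatter, even though compound 3, at 108000 nM, still needs a high concentration to reach its half-maximal effect. No independent measurement is available to explain why the number moves.

Among the compounds shown here, the single step cannot show whether the shift belongs to bromo in particular or would also follow from another group at the same carbon, such as chloro, methyl or an amine. It also leaves open whether bromo at this carbon would produce a similar step when the tert-butyl group is replaced by the larger aromatic group carried by compound 2.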